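Chloro added to the fluorobenzyl arm: cytotoxicity outlook

A few compounds are considered here, and "the series" means these few. Any claim that something is new, unique, unknown or untested is made for them only; others in the source may bear on it.

The series shares the core of compound 1 `Cc1ccc2c(NCc3ccc(NC(=O)C4CCN(Cc5ccc(F)cc5)CC4)cc3)nc(N(C)C)nc2c1`. In a functional assay on SV5A8 cells (Homo sapiens) for cytotoxicity (on this read-out higher numbers stand for weaker inhibition and lower numbers for stronger inhibition), compound 1 gives only a limit of the assay, > 4820 nM. Compound 2 `COc1ccc(CN2CCC(C(=O)Nc3ccc(CNc4nc(N(C)C)nc5cc(C)ccc45)cc3)CC2)cc1` likewise reaches only a limit in this assay, > 6180 nM. Compound 3 `Cc1ccc2c(NCc3ccc(NC(=O)C4CCN(Cc5ncc[nH]5)CC4)cc3)nc(N(C)C)nc2c1` also stops at a limit in this assay, > 20000 nM. Every value shown is therefore a limit and not a number: the limit of > 4820 nM in this assay, at which 1 of the 3 values shown sits, the limit of > 6180 nM in this assay, at which 1 of the 3 values shown sits, and (the limit of > 20000 nM in this assay, at which 1 of the 3 values shown sits). The measured steps are unreadable for the same reason: a step that the two limits leave unreadable from compound 1 to compound 2, a step that the two limits leave unreadable from compound 1 to compound 3 and a step that the two limits leave unreadable from compound 2 to compound 3. Compound 1 thus stands at a limit among three limits, with no ranking possible within the set.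

Compound 4 `Cc1ccc2c(NCc3ccc(NC(=O)C4CCN(Cc5ccc(F)cc5Cl)CC4)cc3)nc(N(C)C)nc2c1` differs from compound 1 by chloro in place of hydrogen on an aromatic carbon. Going by the values given here, no measured step touches this position; the measured exchanges on the benzyl arm, from fluoro to methoxy and from 4-fluorophenyl or 4-methoxyphenyl to 1H-imidazol-2-yl, all left this assay at a limit, so they give no readable size to carry over. No step beyond the scatter is expected in this assay. Compound 4 is expected to give 6000 nM in this assay, within 2500 nM to 20000 nM, most probably again reported as a limit. The expected step is a step that the limit leaves unreadable from compound 1 to compound 4.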

Compound 4, half-maximal inhibitory concentration: > 5910 nM
Compound 4 ended at the assay's limit (the forecaster's own chance of this, stated with the estimate: 80%); the middle value is on the limit's open side.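

In this assay compound 4 gives > 5910 nM, which is a limit of the assay. Going by these compounds alone, compound 1, compound 2 and compound 3 also stand at limits, so no step to or from compound 4 can be read. The compounds shown leave open whether the 2-chloro-4-fluorobenzyl arm changes cytotoxicity relative to the 4-fluorobenzyl arm.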